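Shared core amides: methyl in place of fluoro

The source may report more compounds than this note shows. Statements on the series, on what has been measured and on what is new or still open speak of the compounds shown alone.

Compound 2 `COc1ccc2c(=O)c(/C=C/C(=O)Nc3ccc(F)cc3)coc2c1` carries a 4-fluorophenyl on the amide-type nitrogen of the shared core. In a functional assay on L02 cells (Homo sapiens) for inhibition, read by MTT assay, with a stated time of 48 h (on this read-out higher numbers stand for weaker inhibition and lower numbers for stronger inhibition), compound 2 gives only a limit, > 200000 nM. Compound 1 `COc1ccc2c(=O)c(/C=C/C(=O)Nc3cc(C)ccc3C)coc2c1` carries 2,5-dimethylphenyl on the same nitrogen. In this assay compound 1 likewise gives only a limit, > 200000 nM. Among the compounds with values here, the single measured step in the set, a step that the two limits leave unreadable from compound 1 to compound 2, carries no size, which follows from the limit of > 200000 nM in this assay, at which 2 of the 2 values shown sit. Compound 2 thus stands at the limit of this assay, without a number of its own.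

Compound 3 `COc1ccc2c(=O)c(/C=C/C(=O)Nc3ccc(C)cc3)coc2c1` differs from compound 2 by methyl in place of fluoro on an aromatic carbon. Within the data shown here, no measured step covers a methyl in place of a fluoro on this ring; the only step available is unreadable, so it neither supports nor rules out a move. With both values at the limit, no step beyond the scatter is expected, and the expected step is a number no higher from compound 2 to compound 3 (the limit leaves the size open). For compound 3 the estimate in this assay is 200000 nM, with a range from 60000 nM to 400000 nM, most likely again reported as a limit.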

Compound 3, half-maximal inhibitory concentration: > 200000 nM
Compound 3 gave a limit, no number; the forecaster's own chance of this, stated with the estimate: 85%; the middle value sits exactly at the limit.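

Compound 1, compound 2 and compound 3 all give only limits in this assay, so none of the steps among them can be read: the limit of > 200000 nM in this assay, at which 3 of the 3 values shown sit.

Still open, as far as these compounds go, is how compound 1, compound 2 and compound 3 compare in this assay, including whether methyl in place of fluoro on an aromatic carbon shifts the read-out at all.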